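This account rests on a few compounds, and the source may have more. Where it says the series, first, only, none or still open, it means among the compounds named here.

Within an assay for inhibition of Thromboxane-A synthase (Homo sapiens), using microsomes (a lower number here means a stronger inhibitor, a higher number a weaker inhibitor), compound 3 `CC(C)(Oc1ccccc1O)C1OCC(C/C=C\CCC(=O)O)C(c2cccnc2)O1` gives 32 nM, the lowest of the three numbers recorded. Compound 1 `Cc1ccc(C#N)c(OC(C)(C)C2OCC(C/C=C\CCC(=O)O)C(c3cccnc3)O2)c1` gives 50 nM, and a 1.6-fold lower number from compound 1 to compound 3 (0.19 log units; within the scatter), so the two sit together within the scatter. Compound 2 `Cc1ccc(OC(C)(C)C2OCC(C/C=C\CCC(=O)O)C(c3cccnc3)O2)cc1` gives 360 nM, and an 11-fold lower number from compound 2 to compound 3 (1.05 log units; beyond the scatter), the one clear separation in the set; likewise a 7.2-fold higher number from compound 1 to compound 2 (0.86 log units; beyond the scatter).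

Compound 4 `CC(C)(Oc1ccccc1[N+](=O)[O-])C1OCC(C/C=C\CCC(=O)O)C(c2cccnc2)O1` carries nitro in place of hydroxy on an aromatic carbon. For the measured compounds named here, no measured pair swaps exactly these two groups. Going by the values given here, two steps bear on it: the swap of the whole aryl group from compound 2 to compound 3 moved this assay by a large margin, while the swap from compound 1 to compound 3, which also changes the group sitting ortho to the large group, stayed within the scatter. Both compounds carrying a group at that position, compound 1 and compound 3, sit close together, whereas compound 2, lacking one, stands apart. On this basis a step within the scatter, or at most a modest rise in the number, is expected for a 1.7-fold higher number from compound 3 to compound 4 (0.24 log units; within the scatter).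

For compound 4 the expected value in this assay is 55 nM, with a range from 15 nM to 200 nM.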

Compound 4, half-maximal inhibitory concentration: < 10 nM
Compound 4: only a limit was reported (the forecaster's own chance of this, stated with the estimate: 2%); middle value at least 5.5-fold (0.74 log units) from the limit.
By their numbers in this assay, from the lowest: compounds 3 and 1 (each within the scatter of the next); then compound 2. At a limit, below all of these: compound 4.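

Compound 4 is reported in this assay only as a limit, not as a number: the limit of < 10 nM in this assay, at which 1 of the 4 values shown sits.

Even so, the change on this aromatic carbon, ortho to a large group, reads clearly, with an at least 3.2-fold lower number from compound 3 to compound 4 (0.50 log units; beyond the scatter), so nitro in place of hydroxy gives a step beyond the scatter and a hydrogen-bond donor in this group is not needed for a low number. The earlier compounds shown here could not separate the groups at this place, since compound 1 and compound 3 lie within the scatter of each other, whereas the 2-nitrophenyl group now stands apart from both other aryl groups, with an at least 5.0-fold lower number from compound 1 to compound 4 (0.69 log units; beyond the scatter) and an at least 36-fold lower number from compound 2 to compound 4 (1.55 log units; beyond the scatter).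

Going by these compounds, how far compound 4 lies beyond its limit remains open, and with it the full size of all three steps. Also open, on these data alone, is whether an amine, a methoxy group or a carboxylic acid on the same aromatic carbon would reach the same range as nitro.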